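From 4-chlorobenzyl to 2-methoxybenzyl in an antiproliferative series

A few compounds are considered here, and "the series" means these few. Any claim that something is new, unique, unknown or untested is made for them only; others in the source may bear on it.

In a functional assay on K562 cells (Homo sapiens) for antiproliferative activity, read by MTT assay, with a stated time of 48 h (a higher number here means a weaker inhibitor, a lower number a stronger inhibitor), compound 1 `CCCCc1ccc2c(c1)C(=O)C(=O)N2` gave only a limit, > 10000 nM. Compound 2 `COc1ccc(-c2ccc3c(c2)C(=O)C(=O)N3C)cc1` gave 4980 nM, and compound 3 `COc1ccc(-c2ccc3c(c2)C(=O)C(=O)N3Cc2ccc(Cl)cc2)cc1` gave 350 nM, the lower of these two numbers. Compound 4 `COc1ccc(-c2ccc3c(c2)C(=O)C(=O)N3Cc2ccccc2OC)cc1` has 2-methoxyphenyl in place of 4-chlorophenyl on a saturated chain carbon bound to an amide-type nitrogen in a ring. For the measured compounds named here, compound 4 keeps an aromatic ring there, so it is expected to retain most of the gain seen in a 14-fold lower number from compound 2 to compound 3 (1.15 log units; beyond the scatter), the only measured step bearing on this change. Going by the values given here, no measured pair compares two rings at this place. A modest rise in this assay is expected: a 2.3-fold higher number from compound 3 to compound 4 (0.36 log units; beyond the scatter). For compound 4 the estimate is 800 nM, with an expected range from 250 nM to 2500 nM.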

Compound 4, half-maximal inhibitory concentration: 40 nM
Compound 4: the middle estimate sits 20-fold (1.30 log units) above what was measured; the whole stated range lies above it.
By their numbers in this assay, from the lowest: compound 4; then compound 3; then compound 2. At a limit, above all of these: compound 1.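

The change from 4-chlorobenzyl to 2-methoxybenzyl gave an 8.8-fold lower number from compound 3 to compound 4 (0.94 log units; beyond the scatter) and shows that at this place the groups on the aromatic ring count, not only the presence of the ring. The whole change at this place reaches a 120-fold lower number from compound 2 to compound 4 (2.10 log units; beyond the scatter) and so the gain first seen with compound 3 did not mark the limit of what this place can give. Nothing measured here explains the difference. Open, on these data alone, is whether the gain follows the methoxy group or its ring position: 4-methoxybenzyl or 2-chlorobenzyl would separate these. As far as these compounds go, how an amine or a longer chain would read at this place also remains open.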